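The source may report more compounds than this note shows. Statements on the series, on what has been measured and on what is new or still open speak of the compounds shown alone.

Compound 1 `CC(C)C(=O)NCCS(=O)(=O)NC(=O)c1ccc(Nc2nc(NC3(c4ccc(Cl)cc4)CC3)nc(OCC(F)(F)F)n2)cc1` gives 86%.
Compound 2 `O=C(NS(=O)(=O)CCNC(=O)C1CC1)c1ccc(Nc2nc(NC3(c4ccc(Cl)cc4)CC3)nc(OCC(F)(F)F)n2)cc1` gives 90%.
Compound 3 `CN(C)S(=O)(=O)NC(=O)c1ccc(Nc2nc(NC3(c4ccc(Cl)cc4)CC3)nc(OCC(F)(F)F)n2)cc1` gives 86%.

These three values come from an ADME assay on microsomes from liver (Homo sapiens) for metabolic stability, with a stated time of 10 min; on this read-out higher numbers stand for a more stable compound and lower numbers for a less stable compound. Among them compound 1 stands level with compound 3 at the digits printed, and the two together are the lowest of the three numbers, though the step of a number 4 percentage points higher from compound 1 to compound 2 (within the scatter) is small and within the scatter, as is the step of no change at the digits printed from compound 1 to compound 3 (within the scatter). All three compounds share the same core and differ only in the group attached to the sulfonyl sulfur.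

Compound 4 `NCCS(=O)(=O)NC(=O)c1ccc(Nc2nc(NC3(c4ccc(Cl)cc4)CC3)nc(OCC(F)(F)F)n2)cc1` has not yet been measured in this assay. It differs from compound 1 in one place: hydrogen in place of isopropylcarbonyl on an amine nitrogen. The measured steps that come nearest to this change are no change at the digits printed from compound 1 to compound 3 (within the scatter) and a number 4 percentage points lower from compound 2 to compound 3 (within the scatter), both of which replace a larger group on the sulfonyl sulfur and both of which stay within the scatter. Among the compounds with values here, no measured step removes only the isopropylcarbonyl from the amine nitrogen, so the comparison is indirect.

On that basis the step of a number 2 percentage points lower from compound 1 to compound 4 (within the scatter) is expected to stay within the scatter, with no clear direction. Compound 4 is therefore estimated at 84%, with a range from 68% to 96%.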

Compound 4, percent of the compound remaining: 100%
Compound 4: the middle estimate sits 16 percentage points below what was measured; measured number outside the range, above it.
By their numbers in this assay, from the lowest: compounds 1, 3, 2 and 4 (each within the scatter of the next, the first and the last beyond it).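

Taking the isopropylcarbonyl off the amine nitrogen gives a number 14 percentage points higher from compound 1 to compound 4 (beyond the scatter) in this assay, the first step in this series to pass the scatter, so the group on this nitrogen can matter even though swapping isopropyl for cyclopropyl there did not shift the number beyond the scatter. Compound 3 and compound 4 differ by 2-aminoethyl in place of dimethylamino on the sulfonyl sulfur, and this gives a number 14 percentage points higher from compound 3 to compound 4 (beyond the scatter) as well, whereas hydrogen in place of cyclopropylcarbonyl gives a number 10 percentage points higher from compound 2 to compound 4 (within the scatter) and so does not clear the scatter, which makes the gain real against two of the three neighbours only. Nothing measured here accounts for this step.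

The compounds shown cannot separate the effect of a free amino group at the end of the chain from the simple loss of a larger acyl group. An acetyl or a methyl on that nitrogen, a dimethylamino group at the end of the same chain, or a longer chain such as 3-aminopropyl would help to tell these apart.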